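Replacing the lysine-type side chain in compound 1

The source may hold more compounds than are shown below. What is called first, only, known or untested is meant among the compounds shown, and "the series" means these compounds.

Measured so far in a functional assay on the whole organism (Tail, strain ICR) with Mus musculus as the target, in the tail flick test, with a stated time of 60 min, at a dose of 25 umol/kg by the oral route; a lower number here means a weaker effect, a higher number a stronger effect of the compound at the dose given:
compound 1 `NCCCC[C@H](NC(=O)CN(c1nc(Cl)nc2[nH]cnc12)C1CC1)C(=O)OCc1ccccc1`, 41.2%
compound 2 `O=C(OCc1ccccc1)[C@@H]1CCCN1C(=O)CN(c1ncnc2c1ncn2C1CCCCO1)C1CC1`, 36.7%
compound 3 `NCCCC[C@H](NC(=O)CN(c1nc(Cl)nc2[nH]cnc12)C1CC1)C(=O)O`, 53.8%

Compound 1 stands second highest of the three numbers; its gap to compound 2 lies within the scatter, and compound 3 stands beyond it, by a number 12.6 percentage points higher from compound 1 to compound 3 (beyond the scatter).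

Compound 4 `O=C(CN(c1nc(Cl)nc2[nH]cnc12)C1CC1)N[C@@H](CO)C(=O)OCc1ccccc1` is to be measured. It differs from compound 1 as follows: hydroxy in place of 3-aminopropyl on a saturated chain carbon, two bonds along the chain from an amide-type nitrogen and a carbonyl carbon.

Among the compounds with values here, no measured step touches this change; the only step available is a number 12.6 percentage points higher from compound 1 to compound 3 (beyond the scatter), which concerns the ester end, not the side chain. Compound 2, with a different ring substituent and core, sits within the scatter of compound 1. A step of no more than the scatter is therefore expected, a number 3.2 percentage points lower from compound 1 to compound 4 (within the scatter). For compound 4 the value is estimated at 38%, between 24% and 52%.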

Compound 4, a percentage reported as activity, at one dose (the size of the read-out at that dose, not a potency): 34.2%
The estimate for compound 4 lay 3.8 percentage points above the measured number, and the stated range covers the measured number.
By their numbers in this assay, from the lowest: compounds 4, 2 and 1 (each within the scatter of the next); then compound 3.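

In this assay, hydroxy in place of 3-aminopropyl on this saturated chain carbon gives a number 7 percentage points lower from compound 1 to compound 4 (within the scatter). With the benzyl ester retained, the read-out at this dose therefore does not depend on keeping the 4-aminobutyl chain, and a much shorter hydroxymethyl chain serves as well. Nothing at hand explains this result.

Open, on these data alone, is whether a plain methyl group or a longer hydroxyalkyl chain at this carbon would read the same. Also open, as far as these compounds go, is whether a carboxylic acid in place of the benzyl ester of compound 4 would give a step like a number 12.6 percentage points higher from compound 1 to compound 3 (beyond the scatter).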